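This account rests on a few compounds, and the source may have more. Where it says the series, first, only, none or still open, it means among the compounds named here.

In an ADME assay on HepG2 2.2.15 cells (Homo sapiens) for cytotoxicity (a lower number here means that less compound is tolerated, a higher number that more compound is tolerated), the series reads as follows:
- compound 1 `O=C(OCCc1c(-c2ccccc2Cl)c2cc(Cl)ccc2[nH]c1=O)C1CCCC1` gives 46000 nM
- compound 2 `CC(=O)N1CCC(C(=O)OCCc2c(-c3ccccc3Cl)c3cc(Cl)ccc3[nH]c2=O)CC1` gives 82000 nM
- compound 3 `O=C(OCCc1c(-c2ccccc2Cl)c2cc(Cl)ccc2[nH]c1=O)c1cccs1` gives > 1700000 nM (a limit of the assay, not a number)

Among the measured compounds shown here, compound 3 therefore has no exact position, and the only value at this limit is its own (the limit of > 1700000 nM in this assay, at which 1 of the 3 values shown sits). Compound 4 `O=C(OCCc1c(-c2ccccc2Cl)c2cc(Cl)ccc2[nH]c1=O)c1ccco1` is still unmeasured. It carries furan-2-yl in place of thiophen-2-yl on a carbonyl carbon. Both groups are one five-membered aromatic ring with 1 hetero atom, and they have the same number of heavy atoms.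

Three measured steps change the same place. The first is small (a 1.8-fold higher number from compound 1 to compound 2 (0.25 log units; within the scatter)). The other two are large (an at least 36-fold higher number from compound 1 to compound 3 (1.56 log units; beyond the scatter) and an at least 20-fold higher number from compound 2 to compound 3 (1.31 log units; beyond the scatter)), and both put thiophen-2-yl on the carbonyl carbon. None of the three exchanges one such ring for another, so they bear on this change only indirectly. Compound 4 is expected to stay close to compound 3 in this assay, with no step beyond the scatter in either direction. The risk lies on the lower side, towards compound 2 (82000 nM). The expected step is an at least 1.8-fold lower number from compound 3 to compound 4 (0.27 log units; that floor lies within the scatter), and this estimate can be given only as a limit. For compound 4 the estimate is 900000 nM, with an expected range of 100000 nM to 2500000 nM.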

Compound 4, half-maximal cytotoxic concentration: 98000 nM
The estimate for compound 4 lay 9.2-fold (0.96 log units) above the measured number, outside the stated range (below it).
By their numbers in this assay, from the lowest: compounds 1, 2 and 4 (each within the scatter of the next, the first and the last beyond it). At a limit, above all of these: compound 3.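

In this assay, furan-2-yl and thiophen-2-yl on this carbonyl carbon are not interchangeable, even though both are one five-membered aromatic ring with 1 hetero atom and have the same number of heavy atoms: the exchange of the ring sulfur for oxygen gives an at least 17-fold lower number from compound 3 to compound 4 (1.23 log units; beyond the scatter). Compound 4 instead falls in with the non-aromatic groups, with a 1.2-fold higher number from compound 2 to compound 4 (0.08 log units; within the scatter) and, only modestly beyond the scatter, a 2.1-fold higher number from compound 1 to compound 4 (0.33 log units; beyond the scatter), so among the four groups the high tolerance belongs to thiophen-2-yl alone and not to five-membered aromatic rings as such. Among the compounds shown here, compound 3 is the only compound at a limit of the assay, so its step to compound 4 gives a floor and not a size: the limit of > 1700000 nM in this assay, at which 1 of the 4 values shown sits.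

As far as these compounds go, whether the high tolerance carries over to thiophen-3-yl, phenyl or thiazol-2-yl on this carbonyl carbon stays open, as does whether a methyl group on the thiophen-2-yl ring would keep it. The compounds shown also give no cause for the gap between the two rings, and they leave open whether it would survive an amide in place of the ester.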